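Taking the Carboxymethyl Group Off Compound 2

The source may hold more compounds than are shown below. What is called first, only, known or untested is meant among the compounds shown, and "the series" means these compounds.

In a physicochemical assay for acid dissociation, tested at 10 mM, compound 1 `Cc1nn(-c2ccccc2)c(S)c1C(=O)c1ccccc1` gives 10.3, and compound 2 `Cc1cc(OCc2cc(C)nn2-c2ccccc2)n(CC(=O)O)n1` gives 3.4. Compound 2 therefore holds the lower of the two numbers, and its gap to compound 1 lies beyond the usual scatter. These two compounds differ in more than one place, so no measured single change is available as a guide.

Compound 3 `Cc1cc(OCc2cc(C)nn2-c2ccccc2)[nH]n1` has hydrogen in place of the carboxymethyl of compound 2, on an aromatic nitrogen of a five-membered aromatic ring with 2 nitrogen: hydrogen in place of carboxymethyl on an aromatic nitrogen.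

Compound 1 also has no carboxymethyl and stands at 10.3, so a large upward move is expected in this assay. The expected change, a number 8.10 log units higher from compound 2 to compound 3 (beyond the scatter), would lie well beyond the scatter. For compound 3 the estimated value is 11.5, with an expected range from 9.5 to 14.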

Compound 3, acid dissociation constant: 12.5
Compound 3: middle estimate off by 1.00 log units, on the low side, within the range that was stated.
By their numbers in this assay, from the lowest: compound 2; then compound 1; then compound 3.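

In this assay, among the compounds shown here, the pair of compound 2 and compound 3 gives the first reading of a single change, and it shows that the number can depend heavily on what sits at this position, on an aromatic nitrogen of a five-membered aromatic ring with 2 nitrogen. Hydrogen in place of carboxymethyl moves the value a long way (a number 9.10 log units higher from compound 2 to compound 3 (beyond the scatter)), a large step that compound 1, which differs from both in more than one place, could not reveal. Nothing measured here accounts for the size of this step.

This single replacement leaves open whether an ester or a longer chain ending in an amine on the same nitrogen would give a value close to compound 2 or close to compound 3. It also leaves open whether the same change would give a step of similar size on a different core.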